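The source may hold more compounds than are shown below. What is called first, only, known or untested is meant among the compounds shown, and "the series" means these compounds.

Compound 1 `C=CCOc1nc(N)nc2c1ncn2/C=C1/CC1(CO)CO` and compound 2 `Nc1nc(N2CCCC2)c2ncn(/C=C3/CC3(CO)CO)c2n1` share one core and differ only at the same aromatic carbon. In an ADME assay on MOLT-3 cells (Homo sapiens) for cytotoxicity, with a stated time of 7 days (on this read-out lower numbers stand for higher toxicity in this test and higher numbers for lower toxicity in this test), compound 1 reaches only a limit of the assay, > 20000 nM, and reports no number. For compound 2 this assay gives "not determined" (no result reported), so compound 2 stands without a number of its own. Compound 3 `Nc1nc(SCc2ccccc2)c2ncn(/C=C3/CC3(CO)CO)c2n1` has not yet been measured; it carries benzylsulfanyl in place of pyrrolidin-1-yl on an aromatic carbon. For the measured compounds named here, with no measured step between compounds, no direction is known, and a step within the scatter is as likely as one beyond it. In this assay compound 3 is expected to give 15000 nM, between 4000 nM and 20000 nM.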

Compound 3, half-maximal cytotoxic concentration: > 20000 nM
Compound 3: no number, only a limit (the forecaster's own chance of this, stated with the estimate: 55%); middle value at least 1.3-fold (0.12 log units) from the limit.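

No new step can be read: compound 1 and compound 3 both stop at a limit of the assay, and compound 2 has no number. The compounds shown leave open whether changing the group on this aromatic carbon shifts the cytotoxic concentration at all.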